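A Shorter Amide Side Chain on the Shared Core

The compounds below may be only part of what the source reports. "The series", "measured", "known", "first", "only" and "open" are said of these compounds alone.

Of the compounds shown here, three sharing one core have been tested in an assay (strain Wistar) for inhibition of Amine oxidase [flavin-containing] A (Rattus norvegicus); a higher number here means a weaker inhibitor, a lower number a stronger inhibitor. Compound 1 `NC(=O)[C@@H]1CCCN1c1cc(=O)oc2cc(OCc3ccccc3)ccc12` gives 99800 nM. Compound 3 `NC(=O)[C@@H]1CCCN1Cc1cc(=O)oc2cc(OCc3cccc(F)c3)ccc12` reaches only a limit of this assay, > 100000 nM. Compound 2 `NC(=O)[C@H](CO)Nc1cc(=O)oc2cc(OCc3cccc(Cl)c3)ccc12` likewise gives only a limit, > 100000 nM. This places compound 2 on (the limit of > 100000 nM in this assay, at which 2 of the 3 values shown sit), together with compound 3, while compound 1 alone has a number. Compound 4 `NC(=O)Cc1cc(=O)oc2cc(OCc3cccc(Cl)c3)ccc12` has not been measured yet. It differs from compound 2 in one place: carbamoylmethyl in place of (1-carbamoyl-2-hydroxyethyl)amino on an aromatic carbon, a smaller group without the stereocentre. Within the data shown here, no measured pair differing in one place exists here, so no size of step can be read off; a change beyond the scatter in this assay would show only as a gain. Compound 4 is expected to remain weak, estimated at 80000 nM within 20000 nM to 300000 nM. The expected step of an at least 1.2-fold lower number from compound 2 to compound 4 (0.09 log units; that floor lies within the scatter) stays within the scatter.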

Compound 4, half-maximal inhibitory concentration: 26000 nM
The estimate for compound 4 lay 3.1-fold (0.49 log units) above the measured number; the measured number falls inside the stated range.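

Placing carbamoylmethyl instead of (1-carbamoyl-2-hydroxyethyl)amino on this aromatic carbon, opposite the ring oxygen, gives an at least 3.8-fold lower number from compound 2 to compound 4 (0.58 log units; beyond the scatter) in this assay. This shows that the group at this position can shift the result beyond the scatter, although compound 4 remains a weak inhibitor. Compound 2 has only a limit, so the step has a floor and no exact size: the limit of > 100000 nM in this assay, at which 2 of the 4 values shown sit.

The change alters the amino link, the hydroxyl and the stereocentre together, and the compounds shown do not separate their contributions. As far as these compounds go, how a carboxylic acid or a longer chain would perform at this position also remains open.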